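The source may hold more compounds than are shown below. What is called first, only, known or untested is meant among the compounds shown, and "the series" means these compounds.

Two compounds share one core and differ only in the group carried on the sulfur. Compound 1 `O=c1c2cn(C3COC3)nc2nc(SCc2cccc(F)c2)n1-c1ccccc1` carries a 3-fluorobenzyl group there, and in an assay on PEO1 cells for inhibition of Retinaldehyde dehydrogenase 3 (Homo sapiens), read by flow cytometry, with a stated time of 30 min, tested at 1 uM (on this read-out lower numbers stand for less inhibition and higher numbers for more inhibition at the one concentration tested (going by the name of the read-out)), compound 1 gives 50%. Compound 2 `CC(Sc1nc2nn(C3COC3)cc2c(=O)n1-c1ccccc1)c1ccccn1` carries a 1-(pyridin-2-yl)ethyl group instead, and in this assay compound 2 gives 99%. Going by the values given here, that single exchange produced a number 49 percentage points higher from compound 1 to compound 2 (beyond the scatter), so compound 2 stands highest of the two numbers measured so far, with compound 1 as its nearest neighbour well below it.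

Compound 3 `CC(Sc1nc2nn(C3COC3)cc2c(=O)n1-c1ccccc1)c1cccnc1` is the next step. It differs from compound 2 in one way: pyridin-3-yl in place of pyridin-2-yl on a saturated chain carbon bound to a saturated chain carbon and a sulfur. Among the compounds with values here, the two have the same atoms, joined differently, so this is a smaller change than the one from compound 1 to compound 2, and no measured pair tests a change of this kind. The earlier step shows that this part of the molecule can swing this assay strongly, so some loss is plausible, but a number close to that of compound 2 cannot be ruled out. Compound 3 is therefore expected to give about 80%, most likely between 45% and 99%. The estimated step is a number 19 percentage points lower from compound 2 to compound 3 (beyond the scatter).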

Compound 3, a percentage reported as inhibition, at one concentration (the size of the read-out at that concentration, not a potency): 99%
Compound 3: middle estimate off by 19 percentage points, on the low side, and the stated range covers the measured number.
By their numbers in this assay, from the lowest: compound 1; then compounds 2 and 3 (each within the scatter of the next).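

In this assay the exchange of pyridin-2-yl for pyridin-3-yl gives no change at the digits printed from compound 2 to compound 3 (within the scatter) and so leaves the read-out unmoved: at this position, the test does not separate these two ways of attaching the pyridine ring. The step of a number 49 percentage points higher from compound 1 to compound 3 (beyond the scatter) adds a second point, showing that the large rise over the 3-fluorobenzyl group is not confined to the 1-(pyridin-2-yl)ethyl group, since the 1-(pyridin-3-yl)ethyl group shows it too. No supporting data are available to explain why the two pyridine groups read alike or why either differs from 3-fluorobenzyl.

Compounds 2 and 3 both sit close to the top of a percentage scale at a single concentration, so a real difference in potency between them could stay hidden. Also open, from the compounds shown here alone, is how a 1-(pyridin-4-yl)ethyl group or a plain pyridin-3-ylmethyl group, without the methyl on the chain carbon, would read, which would help show whether the pyridine ring, the branched chain or both account for the rise from compound 1.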